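The source may report more compounds than this note shows. Statements on the series, on what has been measured and on what is new or still open speak of the compounds shown alone.

Compound 1 `CC(C)[C@H](NC(=O)COc1cccc2ccccc12)C(=O)N[C@@H](CC(=O)O)C(=O)CSc1nc(-c2ccccc2)c(-c2ccccc2)o1` gives in a functional assay on Jurkat cells (Homo sapiens) for inhibition (on this read-out higher numbers stand for weaker inhibition and lower numbers for stronger inhibition), the value > 200000 nM, which is a limit of the assay.
Compound 2 `CC(C)[C@H](NC(=O)COc1cccc2ccccc12)C(=O)N[C@@H](CC(=O)O)C(=O)CSc1nc2ccccc2o1` gives > 200000 nM, again a limit of the assay.
Compound 3 `CC(C)[C@H](NC(=O)COc1cccc2ccccc12)C(=O)N[C@@H](CC(=O)O)C(=O)COc1ccc2ccccc2n1` gives > 200000 nM, likewise a limit of the assay.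

All three compounds share one core and differ only in the group attached to the saturated chain carbon bound to a carbonyl carbon. For compound 2 only a limit is known, and the same is true of the two other values, so compound 2 cannot be placed relative to them. For the measured compounds named here, the one step between neighbours, a step that the two limits leave unreadable from compound 2 to compound 3, therefore has no readable size, as the limit of > 200000 nM in this assay, at which 3 of the 3 values shown sit, shows.

Compound 4 `CC(C)[C@H](NC(=O)COc1cccc2ccccc12)C(=O)N[C@@H](CC(=O)O)C(=O)COc1ncnc2ccccc12` carries the change ((quinazolin-4-yl)oxy in place of (1,3-benzoxazol-2-yl)sulfanyl on a saturated chain carbon bound to a carbonyl carbon). Going by the values given here, no measured step speaks for or against this change, since every measurement so far ends at the limit. Compound 4 is therefore expected to give about 300000 nM, between 50000 nM and 2000000 nM. The estimated step that the limit leaves unreadable from compound 2 to compound 4 is expected to be none beyond the scatter, and most likely only a limit will again be reported.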

Compound 4, half-maximal inhibitory concentration: > 200000 nM
Compound 4 gave a limit, no number; the forecaster's own chance of this, stated with the estimate: 85%; the middle value does not contradict the limit.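

Compound 4 ends at a limit like the others, so the steps from compound 2 and from compound 3 to compound 4 cannot be read: the limit of > 200000 nM in this assay, at which 4 of the 4 values shown sit.

The compounds shown leave open whether these groups on the shared core differ at all in this assay, and which group, if any, would give a measurable value.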